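Swapping the vinyl-pyridine arm for a direct pyridine

A few compounds are considered here, and "the series" means these few. Any claim that something is new, unique, unknown or untested is made for them only; others in the source may bear on it.

Measured so far:
Compound 1, `CN1CCN(Cc2ccc(NC(=O)CCSc3ccc4c(/C=C/c5ccccn5)n[nH]c4c3)cc2C(F)(F)F)CC1`, 2480 nM
Compound 2, `O=C(CCSc1ccc2c(/C=C/c3ccccn3)n[nH]c2c1)Nc1ccc(CN2CCCC2)c(C(F)(F)F)c1`, 4000 nM

In an ADME assay on BaF3 cells (Mus musculus) for antiproliferative activity, read by CCK-8 assay, with a stated time of 72 h (on this read-out higher numbers stand for weaker inhibition of growth and lower numbers for stronger inhibition of growth), compound 1 gives 2480 nM. Going by the values given here, its only measured neighbour is compound 2, and the separation between them, a 1.6-fold higher number from compound 1 to compound 2 (0.21 log units; within the scatter), lies within the scatter, so neither compound can be called the stronger of the pair. That single step concerns the saturated chain carbon bound to an aromatic carbon, not the part of the shared core that changes here.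

Compound 3 is `CN1CCN(Cc2ccc(NC(=O)CCSc3ccc4c(-c5ccncc5)n[nH]c4c3)cc2C(F)(F)F)CC1`. It differs from compound 1 as follows: pyridin-4-yl in place of 2-(pyridin-2-yl)ethenyl on an aromatic carbon. Among the compounds with values here, no measured step touches this position, so there is no direct guide to the size or direction of the change in this assay . The expectation for compound 3 is therefore drawn wide, centred near the value of compound 1: a step of a 1.3-fold higher number from compound 1 to compound 3 (0.11 log units; within the scatter), giving an estimated 3200 nM with a range from 800 nM to 13000 nM.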

Compound 3, concentration for 50% growth inhibition: 1060 nM
For compound 3 the middle estimate is 3.0-fold (0.48 log units) above the measured one, and the stated range covers the measured number.
By their numbers in this assay, from the lowest: compound 3; then compounds 1 and 2 (each within the scatter of the next).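

In this assay, going by these compounds alone, this position proves able to move the read-out, with a 2.3-fold lower number from compound 1 to compound 3 (0.37 log units; beyond the scatter) and so stronger inhibition of growth; this is the first step here beyond the scatter, though a modest one. The change does two things at once: the double bond outside the rings is lost, and the pyridine ring is joined through a different ring carbon, so the compounds cannot show which of these matters. Nothing measured here accounts for the gain.

Pyridin-2-yl set directly on the same aromatic carbon, or 2-(pyridin-4-yl)ethenyl, would pull those two changes apart. As far as these compounds go, it also remains open whether a phenyl ring, with no ring nitrogen, would serve as well as pyridin-4-yl, and how pyrrolidin-1-yl would behave alongside pyridin-4-yl.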